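Compound 2 to compound 3: a step from a limit

A few compounds are considered here, and "the series" means these few. Any claim that something is new, unique, unknown or untested is made for them only; others in the source may bear on it.

Compound 1 `CCCC(=O)OC1CCC(CN2CCN(c3cc(=O)c4cc(C(F)(F)F)cc([N+](=O)[O-])c4s3)CC2)CC1` gives > 64 ug/mL as a limit
Compound 2 `COc1cccc(C(=O)OC2CCC(CN3CCN(c4cc(=O)c5cc(C(F)(F)F)cc([N+](=O)[O-])c5s4)CC3)CC2)c1` gives > 64 ug/mL as a limit

Both entries come from an ADME assay on Vero cells (Chlorocebus sabaeus) for cytotoxicity, read by MTT assay, with a stated time of 48 h (a lower number here means a stronger inhibitor, a higher number a weaker inhibitor), and are limits, not numbers. Compound 2 therefore has no exact place on the scale, and the record so far is the limit of > 64 ug/mL in this assay, at which 2 of the 2 values shown sit, and nothing firmer. For the measured compounds named here, the one measured step is a step that the two limits leave unreadable from compound 1 to compound 2 and it puts 3-methoxyphenyl in place of propyl on a carbonyl carbon, so it offers no size to carry forward.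

Compound 3 `CC(=O)NC1CCC(CN2CCN(c3cc(=O)c4cc(C(F)(F)F)cc([N+](=O)[O-])c4s3)CC2)CC1` keeps the shared core and changes one group. The counted difference acetamido in place of ((3-methoxyphenyl)carbonyl)oxy on a saturated ring carbon puts acetamido in place of ((3-methoxyphenyl)carbonyl)oxy on a saturated ring carbon.

Going by the values given here, no measured step bears on this change with a readable size, so no shift beyond the scatter can be expected in either direction. This expectation rests on compound 2 with > 64 ug/mL as a limit and on little else. The expected step is a number no higher from compound 2 to compound 3 (the limit leaves the size open) in this assay and its direction cannot be told. For compound 3 the estimated value is 64 ug/mL within a range from 32 ug/mL to 128 ug/mL and the assay may well report only a limit again.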

Compound 3, half-maximal inhibitory concentration: > 64 ug/mL
Compound 3: a limit, no number; the forecaster's own chance of this, stated with the estimate: 80%; the middle value sits exactly at the limit.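

In this assay compound 3 gives > 64 ug/mL as a limit, not a number. For the compounds shown here, no step among compound 1, compound 2 and compound 3 can be read, and the record still holds only limits: the limit of > 64 ug/mL in this assay, at which 3 of the 3 values shown sit.

The compounds shown leave open where each of the three truly lies on the scale and how far apart they stand.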